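The source may report more compounds than this note shows. Statements on the series, on what has been measured and on what is new or still open speak of the compounds shown alone.

Measured in a functional assay on HCT-116 cells (Homo sapiens) for inhibition, read by MTT assay, with a stated time of 72 h; on this read-out higher numbers stand for weaker inhibition and lower numbers for stronger inhibition:
- compound 1 `CC1=NN(c2ccccc2)C(=O)[C@]12C(=O)C=CC[C@H]2c1ccc(C)cc1`: 4220 nM
- compound 2 `CC1=NN(c2ccccc2)C(=O)[C@@]12C(=O)C=CC[C@H]2c1ccc(C)cc1`: 5210 nM
- compound 3 `CC1=NN(c2ccccc2)C(=O)[C@@]12C(=O)C=CC[C@@H]2c1ccc(C)cc1`: 5220 nM

These three compounds have the same atoms and bonds and differ only in configuration as drawn. Compound 3 stands level with the other two, since a 1.0-fold higher number from compound 2 to compound 3 (0.00 log units; within the scatter) and a 1.2-fold higher number from compound 1 to compound 3 (0.09 log units; within the scatter) are both within the scatter.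

Compound 4 `CC1=NN(c2ccccc2)C(=O)[C@]12C(=O)C=CC[C@@H]2c1ccc(C)cc1` has not yet been measured. It differs from compound 3 as follows: the two compounds have the same atoms and bonds and differ only in configuration as drawn: 1 of 2 stereo elements differ; a stereocentre at a saturated ring carbon is drawn R in compound 3 and S in compound 4. A stereocentre at a saturated ring carbon is drawn R in compound 3 and S in compound 4, and nothing else changes.

The closest precedents are the other steps that invert a single stereocentre. These are a 1.2-fold higher number from compound 1 to compound 2 (0.09 log units; within the scatter) and a 1.0-fold higher number from compound 2 to compound 3 (0.00 log units; within the scatter), and neither goes beyond the scatter. Inverting all stereocentres did no more, as a 1.2-fold higher number from compound 1 to compound 3 (0.09 log units; within the scatter) also stays within the scatter. In this assay, configuration has therefore not moved the numbers in any of the measured pairs, and no step beyond the scatter is expected in either direction.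

The expected step is small, namely a 1.1-fold lower number from compound 3 to compound 4 (0.03 log units; within the scatter).

The estimate for compound 4 is 4900 nM, with an expected range from 3300 nM to 7200 nM.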

Compound 4, half-maximal inhibitory concentration: 5800 nM
Estimate against measurement, compound 4: 1.2-fold (0.07 log units) below, and the stated range covers the measured number.
By their numbers in this assay, from the lowest: compounds 1, 2, 3 and 4 (each within the scatter of the next).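

With compound 4 in place, all four combinations of the two stereocentres can be compared in this assay, and the last one adds no separation: inverting one stereocentre gives a 1.1-fold higher number from compound 3 to compound 4 (0.05 log units; within the scatter), inverting the other gives a 1.4-fold higher number from compound 1 to compound 4 (0.14 log units; within the scatter), and inverting both gives a 1.1-fold higher number from compound 2 to compound 4 (0.05 log units; within the scatter). The earlier compounds shown here had tested each stereocentre with the other held in only one configuration, whereas these steps test each with the other held in the opposite configuration, and a second mirror-image pair now stays within the scatter like the first. The insensitivity to configuration at these two positions therefore holds across the whole set of stereoisomers, and any step here can be read as one of configuration alone: the fact that compounds 3 and 4 differ only in the configuration as drawn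

What the four compounds leave open is whether configuration would stay this silent on a core carrying a different group, such as an amine or a carboxylic acid. They also leave open whether the same flat picture would appear in any read-out other than this assay, and what, in the shared structure, sets the level of these numbers.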